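This account rests on a few compounds, and the source may have more. Where it says the series, first, only, none or still open, it means among the compounds named here.

Compound 1 `Cc1c(C2CC2)nc2ccc(-n3ccc(OCc4ccc(Br)cc4)cc3=O)cn12` stands at the lower of the two numbers recorded in an assay on CHO cells for displacement of a labelled ligand from melanin-concentrating hormone receptor 1 (Rattus norvegicus), read by scintillation counting, with a stated time of 1 h; on this read-out lower numbers stand for stronger inhibition and higher numbers for weaker inhibition. In this assay compound 1 gives 9.3 nM. The other measured compound, compound 2 `CCc1nc2ccc(-n3ccc(OCc4ccccc4)cc3=O)cn2c1C`, gives 120 nM in this assay, and the gap between these two values lies beyond the scatter; compounds 1 and 2 differ in more than one place, so their two values show that gap and nothing more about any single change.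

Compound 3 `Cc1c(C2CC2)nc2ccc(-n3ccc(OCc4csc(C(F)(F)F)c4)cc3=O)cn12` is reached from compound 1 by one change: 5-(trifluoromethyl)thiophen-3-yl in place of 4-bromophenyl on a saturated chain carbon bound to an oxygen on an aromatic ring. Within the data shown here, no pair of measured compounds carries this change, so the expectation for compound 3 rests on the value of compound 1 alone. In this assay the expected step is a 1.6-fold higher number from compound 1 to compound 3 (0.21 log units; within the scatter), small and toward a somewhat higher number, if it reaches beyond the scatter at all. Compound 3 is therefore estimated to give 15 nM in this assay, with a range from 4 nM to 60 nM.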

Compound 3, half-maximal inhibitory concentration: 15 nM
The estimate for compound 3 equals the measured number at the digits printed, and the stated range covers the measured number.
By their numbers in this assay, from the lowest: compounds 1 and 3 (each within the scatter of the next); then compound 2.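

In this assay, putting 5-(trifluoromethyl)thiophen-3-yl in place of 4-bromophenyl on a saturated chain carbon bound to an oxygen on an aromatic ring gives a 1.6-fold higher number from compound 1 to compound 3 (0.21 log units; within the scatter). This is the only step shown that isolates a change at this position, since compounds 1 and 2 differ in more than one place. It shows that a five-membered aromatic ring with 1 hetero atom can stand in for a six-membered aromatic ring of carbon only here without a shift beyond the scatter, even though the entering group has 9 heavy atoms against 7 and 1 hydrogen-bond acceptor against 0. Nothing measured here explains how closely these two groups match in this read-out.

As far as these compounds go, it remains open whether the same holds for a quite different group at this place, such as an amine or a carboxylic acid. Compound 2 carries an unsubstituted phenyl on its chain carbon but also differs from compound 1 elsewhere, so what the bromine alone contributes is unresolved.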